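Replacing an Aryl Group by an Alkyl Chain

The compounds below may be only part of what the source reports. "The series", "measured", "known", "first", "only" and "open" are said of these compounds alone.

Compound 1: `COc1cc(N)c(Cl)cc1NC(=O)C1CCN(Cc2cccc(C#N)c2)CC1`, > 4 mg/kg
Compound 2: `COc1cc(N)c(Cl)cc1NC(=O)C1CCN(Cc2ccc(C)c(C)c2)CC1`, > 8 mg/kg

In a functional assay on the whole organism for antagonist activity, with Mus musculus as the target (on this read-out higher numbers stand for an effect only at larger amounts of compound and lower numbers for an effect already at smaller amounts), compound 1 gives only a limit, > 4 mg/kg. Compound 2 likewise gives only a limit in this assay, > 8 mg/kg. Because both values are limits the limit of > 4 mg/kg in this assay, at which 1 of the 2 values shown sits, and (the limit of > 8 mg/kg in this assay, at which 1 of the 2 values shown sits), the step that the two limits leave unreadable from compound 1 to compound 2 cannot be read in either direction, so compound 2 stands on a limit and no number.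

Compound 3, `CCCCCN1CCC(C(=O)Nc2cc(Cl)c(N)cc2OC)CC1`, has not yet been measured in this assay. It differs from compound 2 by butyl in place of 3,4-dimethylphenyl on a saturated chain carbon bound to an amine nitrogen in a ring. No measured step bears on this change, since the only step shown, a step that the two limits leave unreadable from compound 1 to compound 2, is unreadable. With nothing to carry over, compound 3 is expected to sit near the limit of compound 2, the step that the limit leaves unreadable from compound 2 to compound 3 being an estimate and not a reading. Compound 3 is therefore estimated at 10 mg/kg, within 3 mg/kg to 30 mg/kg.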

Compound 3, dose for half-maximal effect: > 10 mg/kg
Compound 3: no number, only a limit; the forecaster's own chance of this, stated with the estimate: 70%; the middle value sits exactly at the limit.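

In this assay compound 3 gives only a limit, > 10 mg/kg. Compounds 1 and 2 also stand on limits, so neither step to compound 3 can be read. The compounds shown leave open whether butyl, 3,4-dimethylphenyl or 3-cyanophenyl in this place changes the effect at all.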